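The source may report more compounds than this note shows. Statements on the series, on what has been measured and on what is new or still open speak of the compounds shown alone.

Working notes on the series in a functional assay on Ehrlich cells (Mus musculus) for antiproliferative activity, read by trypan blue exclusion, with a stated time of 2 h, tested at 100 ug/mL; a lower number here means a weaker effect, a higher number a stronger effect of the compound at the concentration tested.

Three members of the series have numbers. Compound 1 `COc1cc(CC2C(C#N)=C(N)N(c3ccc(S(N)(=O)=O)cc3)C3=C2C(=O)CCC3)ccc1O` gives 100%. Compound 2 `N#CC1=C(N)N(c2ccc(S(N)(=O)=O)cc2)C2=C(C(=O)CCC2)C1c1cccc([N+](=O)[O-])c1` gives 71%. Compound 3 `COc1ccc2ccccc2c1C1C(C#N)=C(N)N(c2ccc(S(N)(=O)=O)cc2)C2=C1C(=O)CCC2` gives 80%, which places compound 3 second highest of the three: its gap to compound 2 is within the scatter, while a number 20 percentage points lower from compound 1 to compound 3 (beyond the scatter) is beyond it.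

Compound 4 `N#CC1=C(N)N(c2ccc(S(N)(=O)=O)cc2)C2=C(C(=O)CCC2)C1c1ccco1` has no number yet. Its change from compound 3 is furan-2-yl in place of 2-methoxynaphthalen-1-yl on a saturated ring carbon, so again a different aromatic group on the same saturated ring carbon.

Two measured steps are of this kind. Replacement of the group on that carbon gave a number 29 percentage points lower from compound 1 to compound 2 (beyond the scatter) and a number 20 percentage points lower from compound 1 to compound 3 (beyond the scatter), both modest and downward, while a number 9 percentage points higher from compound 2 to compound 3 (within the scatter) stayed within the scatter. Swaps among the aromatic groups on this carbon have therefore moved this assay by modest amounts at most, with no step upward beyond the scatter from compound 3.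

For compound 4 a step of a number 6 percentage points lower from compound 3 to compound 4 (within the scatter) is expected, most likely within or near the scatter. Compound 4 is estimated at 74%, with a range from 55% to 93%.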

Compound 4, a percentage reported as activity, at one concentration (the size of the read-out at that concentration, not a potency): 10%
For compound 4 the middle estimate is 64 percentage points above the measured one; the whole stated range lies above it.
By their numbers in this assay, from the lowest: compound 4; then compounds 2 and 3 (each within the scatter of the next); then compound 1.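

In this assay the saturated ring carbon proves far less forgiving than the earlier swaps suggested: furan-2-yl in place of 2-methoxynaphthalen-1-yl gives a number 70 percentage points lower from compound 3 to compound 4 (beyond the scatter) as a large step. The loss does not depend on the group replaced, for furan-2-yl in place of 3-nitrophenyl gives a number 61 percentage points lower from compound 2 to compound 4 (beyond the scatter) and furan-2-yl in place of 4-hydroxy-3-methoxybenzyl gives a number 90 percentage points lower from compound 1 to compound 4 (beyond the scatter) in the same assay. Among these four compounds, furan-2-yl alone brings a five-membered aromatic ring with a hetero atom to this carbon, and it alone falls so far.

No measured evidence accounts for the drop. As far as these compounds go, whether it follows the five-membered ring or its ring oxygen stays open, and thiophen-2-yl or plain phenyl on the same carbon would help separate the two.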